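This account rests on a few compounds, and the source may have more. Where it says the series, first, only, none or still open, it means among the compounds named here.

Measured so far:
compound 1 `Cc1ccc2[nH]c(=O)c(CN(Cc3ccc(F)cc3)Cc3cccc4ccccc34)cc2c1` — > 5000 nM
compound 2 `CCc1ccc2[nH]c(=O)c(CN(Cc3ccc(F)cc3)Cc3cccc4ccccc34)cc2c1` — > 5000 nM
compound 3 `Cc1ccc2cc(CN(Cc3ccc(C(C)(C)C)cc3)C3CCCC3)c(=O)[nH]c2c1` — > 10000 nM

In a toxicity assay on MDCK cells (Canis lupus familiaris) for cytotoxicity, read by crystal violet staining, with a stated time of 48 h (on this read-out lower numbers stand for higher toxicity in this test and higher numbers for lower toxicity in this test), compound 1 gives > 5000 nM, which is a limit of the assay and not a number. Compound 2 gives > 5000 nM, likewise a limit. Compound 3 gives > 10000 nM, also a limit. The change from compound 1 to compound 2 is methyl in place of hydrogen on a saturated chain carbon bound to an aromatic carbon, and the step that the two limits leave unreadable from compound 1 to compound 2 stays unreadable because both values sit at the limit of > 5000 nM in this assay, at which 2 of the 3 values shown sit. How the core of compound 1 differs from the core of compound 3 is not broken down here. Compound 4 `CCc1ccc2cc(CN(Cc3ccc(C(C)(C)C)cc3)C3CCCC3)c(=O)[nH]c2c1` carries the same change on the core of compound 3, namely (methyl in place of hydrogen on a saturated chain carbon bound to an aromatic carbon), at a place described in the same words. The expected step is a step that the limit leaves unreadable from compound 3 to compound 4, resting on compound 3 sitting at the limit of > 10000 nM in this assay, at which 1 of the 3 values shown sits, and on the unreadable step from compound 1 to compound 2. Compound 4 is expected near 12000 nM, between 5000 nM and 40000 nM, most likely again reported as a limit.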

Compound 4, half-maximal cytotoxic concentration: > 9000 nM
Compound 4 ended at the assay's limit; the forecaster's own chance of this, stated with the estimate: 75%; the middle value does not contradict the limit.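

Compound 3 gives > 10000 nM, a limit, and compound 4 gives > 9000 nM, also a limit, so no step can be read between compound 3 and compound 4. As far as these compounds go, whether methyl to ethyl changes cytotoxicity on either core stays open.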